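Aminothiophene ketone series: piperazine nitrogen substituent and receptor response

This account rests on a few compounds, and the source may have more. Where it says the series, first, only, none or still open, it means among the compounds named here.

Measured compounds:
- compound 1 `CC(C)N1CCN(Cc2csc(N)c2C(=O)c2ccc(Cl)cc2)CC1`, in a functional assay on CHO cells with adenosine receptor A1 (Homo sapiens) as the target, read by cAMP accumulation and immunoassay, with a stated time of 6 min, tested at 0.1 uM (a lower number here means a stronger effect, a higher number a weaker effect of the compound at the concentration tested), compound 1 gives 3.6%
- compound 2 `COc1ccc(N2CCN(Cc3csc(N)c3C(=O)c3ccc(Cl)cc3)CC2)cc1`, compound 2 gives 0%
- compound 3 `Nc1scc(CN2CCN(C3CCCCCC3)CC2)c1C(=O)c1ccc(Cl)cc1`, compound 3 gives 13%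

Compound 2 stands lowest of the three numbers in this assay; compound 1 lies nearest, with a number 3.6 percentage points lower from compound 1 to compound 2 (within the scatter), and compound 3 furthest, with a number 13 percentage points higher from compound 2 to compound 3 (beyond the scatter). The step from compound 1 to compound 3, a number 9.4 percentage points higher from compound 1 to compound 3 (within the scatter), also stays inside the scatter.

Compound 4 `Nc1scc(CN2CCN(c3cc(F)ccc3F)CC2)c1C(=O)c1ccc(Cl)cc1` has not been measured. Relative to compound 2 it differs as follows: 2,5-difluorophenyl in place of 4-methoxyphenyl on an amine nitrogen in a ring. The measured steps that bear on this change are those at the same ring nitrogen: an aryl group replacing isopropyl gave a number 3.6 percentage points lower from compound 1 to compound 2 (within the scatter), and a saturated ring replacing the aryl group gave a number 13 percentage points higher from compound 2 to compound 3 (beyond the scatter). For the measured compounds named here, no measured step exchanges one aryl group for another, so the effect of swapping the substituent pattern on the aryl ring is unknown. All three numbers lie at the low end of the scale and two of the three steps are within scatter, so a small step, if any, is expected.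

Compound 4 is therefore expected to give 4% in this assay, between 0% and 14%. The expected step from compound 2 to compound 4 is a number 4 percentage points higher from compound 2 to compound 4 (within the scatter), within the scatter.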

Compound 4, a percentage reported as activity, at one concentration (the size of the read-out at that concentration, not a potency): -13%
Beside the measured number, compound 4's estimate is 17 percentage points above it, and the stated range ends above it.
By their numbers in this assay, from the lowest: compound 4; then compounds 2, 1 and 3 (each within the scatter of the next, the first and the last beyond it).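

Exchanging one aryl group for another on the ring nitrogen moves the result in this assay beyond the scatter (a number 13 percentage points lower from compound 2 to compound 4 (beyond the scatter)), so at this position the substitution on the aryl ring counts, and not only the choice between an aryl group and a saturated one. The 2,5-difluorophenyl group also stands apart, beyond the scatter, from both non-aryl groups (a number 16.6 percentage points lower from compound 1 to compound 4 (beyond the scatter); a number 26 percentage points lower from compound 3 to compound 4 (beyond the scatter)), whereas compound 2 stood clear only of compound 3, and compound 4 alone gives a negative number. Nothing at hand accounts for these steps.

Still open, from the compounds shown here alone, is whether the step from compound 2 follows the fluorine atoms, their placement on the ring or the absence of the methoxy group. A single chlorine on the phenyl ring, a pyridine ring or a benzyl group on the same nitrogen would help separate these readings.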